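This account rests on a few compounds, and the source may have more. Where it says the series, first, only, none or still open, it means among the compounds named here.

Compound 3 `CS(=O)(=O)NC(=O)c1ccc(Nc2nc(NC3(c4ccc(Cl)cc4)CC3)nc(OCC(F)(F)F)n2)cc1` sits, in an ADME assay on microsomes from liver (Homo sapiens) for metabolic stability, with a stated time of 10 min (a higher number here means that more of the compound is left, a lower number that less of the compound is left), at 100%, level with compound 1 `CC(C)OC(=O)NCCS(=O)(=O)NC(=O)c1ccc(Nc2nc(NC3(c4ccc(Cl)cc4)CC3)nc(OCC(F)(F)F)n2)cc1`, which gives 100%, the pair forming the highest numbers of the three; compound 2 `CC(C)(C)CNCCS(=O)(=O)NC(=O)c1ccc(Nc2nc(NC3(c4ccc(Cl)cc4)CC3)nc(OCC(F)(F)F)n2)cc1` gives 89%. Compound 4 `NCCS(=O)(=O)NC(=O)c1ccc(Nc2nc(NC3(c4ccc(Cl)cc4)CC3)nc(OCC(F)(F)F)n2)cc1` differs from compound 3 by aminomethyl in place of hydrogen on a saturated chain carbon bound to a sulfonyl sulfur. Among the compounds with values here, two measured steps touch the same carbon: no change at the digits printed from compound 1 to compound 3 (within the scatter) and a number 11 percentage points higher from compound 2 to compound 3 (beyond the scatter). A large substituent on that carbon thus left the number either unchanged or modestly lower, so for compound 4 the aminomethyl is expected to cost little or nothing, giving an expected a number 5 percentage points lower from compound 3 to compound 4 (within the scatter). Compound 4 is therefore estimated at 95%, within a range of 80% to 100%.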

Compound 4, percent of the compound remaining: 100%
For compound 4 the middle estimate is 5 percentage points below the measured one; the measured number falls inside the stated range.
By their numbers in this assay, from the lowest: compound 2; then compounds 1, 3 and 4 (each within the scatter of the next).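

In this assay the bare aminomethyl on the saturated chain carbon bound to a sulfonyl sulfur gives no change at the digits printed from compound 3 to compound 4 (within the scatter), so a free amine at this position stands level with the methanesulfonamide. Removing the substituent from the amine nitrogen gives no change at the digits printed from compound 1 to compound 4 (within the scatter) for isopropoxycarbonyl and a number 11 percentage points higher from compound 2 to compound 4 (beyond the scatter) for neopentyl, so of the two substituents only neopentyl is set apart from the free amine by a step beyond the scatter. Nothing shown gives a reason for these results. Going by these compounds, whether a longer chain, a carboxylic acid or a dimethylamine at this position would stay level remains open.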